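The source may report more compounds than this note shows. Statements on the series, on what has been measured and on what is new or still open speak of the compounds shown alone.

Among the measured compounds shown here, compound 1 `CC(=O)N1N=C(Nc2nc3ccc(Cl)cc3s2)CC1c1ccc(O)cc1` is the only compound in this set with a numerical result. In a functional assay on the whole organism (strain albino) with Mus musculus as the target, with a stated time of 0.5 h (a lower number here means that less compound is needed, a higher number that more compound is needed for the effect), compound 1 gives 107 umol/kg. A second compound, compound 2 `CC(=O)N1N=C(Nc2nc3ccc([N+](=O)[O-])cc3s2)CC1c1ccc(O)cc1`, was also entered in this assay, but for compound 2 the outcome is "not determined" (no result reported), so no number stands behind it and it offers no comparison.

The step of interest leads to compound 3 `CC(=O)N1N=C(Nc2nc3ccc(Cl)cc3s2)CC1c1ccc(Cl)cc1`, which differs from compound 1 in a single place: chloro in place of hydroxy on an aromatic carbon. For the measured compounds named here, since no measured pair shows what this kind of swap does in this assay, there is no basis for predicting a shift in either direction, and the most reasonable expectation is a step close to nothing, though with wide uncertainty. The step expected is a 1.2-fold higher number from compound 1 to compound 3 (0.08 log units; within the scatter), which would stay within the usual scatter. Compound 3 is therefore expected to need about 130 umol/kg in this assay, somewhere between 45 umol/kg and 380 umol/kg.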

Compound 3, dose for half-maximal effect: 81.5 umol/kg
For compound 3 the middle estimate is 1.6-fold (0.20 log units) above the measured one; measured number inside the range.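

Replacing the 4-hydroxyphenyl group with 4-chlorophenyl gives a 1.3-fold lower number from compound 1 to compound 3 (0.12 log units; within the scatter) in this assay, so the two compounds cannot be told apart in this whole-animal read-out. At this place on the six-membered aromatic ring, then, a hydroxy group with its hydrogen-bond donor and acceptor is not needed for a measurable effect, since compound 3 has a chloro group with neither and still gives a number of the same size as compound 1. Nothing at hand explains why the two groups read alike.

On these data alone, whether an amine, a carboxylic acid or a longer chain at this place would also stay within the scatter remains open. This single pair also cannot show whether the same swap would read alike with a different group elsewhere on the shared core.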